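Methyl addition tested across two oxadiazole cores

The compounds below may be only part of what the source reports. "The series", "measured", "known", "first", "only" and "open" are said of these compounds alone.

Compound 1 `Cc1ccc(C(=O)CCc2nnc(-c3ccc(Cl)cc3)o2)cc1` gives 81.5% in a functional assay on the whole organism (strain Wistar) for inhibition, with Rattus norvegicus as the target, with stated times of 30 min and 3 h, at a dose of 20 mg/kg by the oral route; a lower number here means less inhibition, a higher number more inhibition at the dose given (going by the name of the read-out). Compound 2 `Cc1ccc(C(=O)CCc2nnc(-c3ccc(Cl)cc3)o2)c(C)c1` differs by methyl in place of hydrogen on an aromatic carbon and gives 72.6%, so a number 8.9 percentage points lower from compound 1 to compound 2 (within the scatter). Compound 3 `Cc1ccc(C(=O)CCc2nnc(Cc3ccccc3)o2)cc1` carries a different core, the difference being (benzyl in place of 4-chlorophenyl on an aromatic carbon); in this assay compound 3 gives 51.9%, and the step is a number 29.6 percentage points lower from compound 1 to compound 3 (beyond the scatter). Compound 4 `Cc1ccc(C(=O)CCc2nnc(Cc3ccccc3)o2)c(C)c1`, not yet measured, repeats the same change on the core of compound 3, namely (methyl in place of hydrogen on an aromatic carbon), with the surroundings of the place identical to those in the step from compound 1 to compound 2. Because the earlier step was a number 8.9 percentage points lower from compound 1 to compound 2 (within the scatter), the expected step is a number 7.9 percentage points lower from compound 3 to compound 4 (within the scatter). For compound 4 the estimated value in this assay is 44%, expected to fall between 26% and 60%, with a single earlier step as the basis.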

Compound 4, a percentage reported as inhibition, in the whole organism at one dose (the size of the read-out at that dose, not a potency): 50%
Compound 4: middle estimate off by 6 percentage points, on the low side, within the range that was stated.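

In this assay, the methyl step on the second core is a number 1.9 percentage points lower from compound 3 to compound 4 (within the scatter), and it agrees with the step on the first core: the same change on two cores in this assay, a number 8.9 percentage points lower (within the scatter) from compound 1 to compound 2 and a number 1.9 percentage points lower (within the scatter) from compound 3 to compound 4, 7 percentage points apart, within the scatter of two such steps. The swap of 4-chlorophenyl for benzyl, read with the extra methyl present, is a number 22.6 percentage points lower from compound 2 to compound 4 (beyond the scatter), and it also carries over: the same change on two cores in this assay, a number 29.6 percentage points lower (beyond the scatter) from compound 1 to compound 3 and a number 22.6 percentage points lower (beyond the scatter) from compound 2 to compound 4, 7 percentage points apart, within the scatter of two such steps. This shows that each change gave a similar step on these two cores at a single dose, but both methyl steps lie within the scatter, so it does not show that the methyl itself does anything, or that the agreement would hold on other cores.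

On these data alone, whether a methoxy group or a chlorine atom in place of that methyl would give a step beyond the scatter remains open. Also open, as far as these compounds go, is what a longer chain in place of the one carrying the carbonyl would do.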